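Adding Fluoro to a Short-Lived Compound

A few compounds are considered here, and "the series" means these few. Any claim that something is new, unique, unknown or untested is made for them only; others in the source may bear on it.

Measured in an in vitro ADME assay on microsomes from liver (Homo sapiens) for metabolic stability; on this read-out higher numbers stand for a longer-lived compound and lower numbers for a shorter-lived compound:
Compound 1 `CC(C)CC1n2cncc2CN(Cc2ccc(OC(F)(F)F)cc2)S1(=O)=O`: 0.117 h
Compound 2 `CC(C)CC1n2cncc2CN(Cc2ccccc2)S1(=O)=O`: 0.05 h

Compound 2, at 0.05 h, holds the lower of the two numbers. Compound 3 `CC(C)CC1n2cncc2CN(Cc2ccc(F)cc2)S1(=O)=O` has fluoro in place of hydrogen on an aromatic carbon of compound 2: fluoro in place of hydrogen on an aromatic carbon. Going by the values given here, the one measured step that bears on this is a 2.3-fold lower number from compound 1 to compound 2 (0.37 log units; beyond the scatter), a modest step with hydrogen replacing trifluoromethoxy. It involves a different group and is only a loose guide, so a smaller rise in the same direction is expected: a 1.4-fold higher number from compound 2 to compound 3 (0.15 log units; within the scatter). For compound 3 the estimate is 0.07 h, with an expected range from 0.04 h to 0.12 h.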

Compound 3, half-life: 0.0833 h
Estimate against measurement, compound 3: 1.2-fold (0.08 log units) below; the measured number falls inside the stated range.
By their numbers in this assay, from the lowest: compounds 2, 3 and 1 (each within the scatter of the next, the first and the last beyond it).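

In this assay, fluoro on an aromatic carbon para to a large group gives a step within the scatter (a 1.7-fold higher number from compound 2 to compound 3 (0.22 log units; within the scatter)). Fluoro and trifluoromethoxy at this place also fall within the scatter of each other (a 1.4-fold lower number from compound 1 to compound 3 (0.15 log units; within the scatter)), so compound 3 cannot be separated from either neighbour, although compound 1 and compound 2 do separate. Nothing here gives a reason for these numbers.

Still open, from the compounds shown here alone, is how an amine, a carboxylic acid or a nitrile would read at this place. Fluoro on other carbons of this ring also remains open.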